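Aryl group on the ring nitrogen: compound 4 outlook

A few compounds are considered here, and "the series" means these few. Any claim that something is new, unique, unknown or untested is made for them only; others in the source may bear on it.

Measured compounds:
compound 1 `COc1ccccc1N1C(=O)CSC1C(=O)NCCCCc1ccccc1`: 60%
compound 2 `Cc1cccc(N2C(=O)CSC2c2cccc(C(=O)NCCCCc3ccccc3)c2)c1`: 93%
compound 3 `CCN1C(=O)CSC1c1cccc(C(=O)NCCCCc2ccccc2)c1`: 0%

In a functional assay on MG-63 cells (Homo sapiens) for inhibition, read by CCK-8 assay, with a stated time of 72 h, tested at 1 uM (a lower number here means less inhibition, a higher number more inhibition at the concentration tested (going by the name of the read-out)), compound 2 gives the highest of the three numbers, and its step to each of the others lies beyond the scatter. Compound 4 `COc1cccc(OC)c1N1C(=O)CSC1c1cccc(C(=O)NCCCCc2ccccc2)c1` differs from compound 2 in one place: 2,6-dimethoxyphenyl in place of 3-methylphenyl on an amide-type nitrogen in a ring. Going by the values given here, the only measured step at this position is a number 93 percentage points lower from compound 2 to compound 3 (beyond the scatter), which shows that an aryl group on the ring nitrogen matters in this assay. Compound 1 carries a methoxy-bearing aryl group on the same ring nitrogen but on a different core, so it gives only a loose reference. Since compound 4 keeps an aryl group here, a modest drop is expected, a number 23 percentage points lower from compound 2 to compound 4 (beyond the scatter). Compound 4 is estimated at 70%, range 35% to 95%.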

Compound 4, a percentage reported as inhibition, at one concentration (the size of the read-out at that concentration, not a potency): 80%
For compound 4 the middle estimate is 10 percentage points below the measured one; measured number inside the range.
By their numbers in this assay, from the lowest: compound 3; then compound 1; then compound 4; then compound 2.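

In this assay a second aryl group on the shared core gives a number 80 percentage points higher from compound 3 to compound 4 (beyond the scatter) and so the high number is not confined to 3-methylphenyl. The swap to 2,6-dimethoxyphenyl gives only a number 13 percentage points lower from compound 2 to compound 4 (beyond the scatter) and so this position takes a group with two added methoxy substituents at a modest cost. Nothing measured explains the gap between the aryl groups and ethyl.

Open, from the compounds shown here alone, is whether an aromatic ring is needed at all, since cyclohexyl or a longer chain such as hexyl would test that. Open too, going by these compounds, is how an aryl group bearing an amine or a carboxylic acid would behave here.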